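The source may hold more compounds than are shown below. What is called first, only, known or untested is meant among the compounds shown, and "the series" means these compounds.

Compound 1 `COc1cc(Oc2ccc(NC(=O)Nc3cccc(C(F)(F)F)c3)cc2)ncn1`: in an assay on isolated protein for inhibition of serine/threonine-protein kinase TNNI3K (Homo sapiens) (on this read-out higher numbers stand for weaker inhibition and lower numbers for stronger inhibition), compound 1 gives 4000 nM.
Compound 2 `CCCNc1cc(Oc2ccc(NC(=O)Nc3cccc(C(F)(F)F)c3)cc2)ncn1`: in this assay compound 2 gives 32 nM.
Compound 3 `Cc1cc(Oc2ccc(NC(=O)Nc3cccc(C(F)(F)F)c3)cc2)ncn1`: in this assay compound 3 gives 160 nM.

Among these three, compound 3 stands with the second highest number: it is a 5.0-fold higher number from compound 2 to compound 3 (0.70 log units; beyond the scatter) and a 25-fold lower number from compound 1 to compound 3 (1.40 log units; beyond the scatter). Compound 4 `C[C@H](O)CNc1cc(Oc2ccc(NC(=O)Nc3cccc(C(F)(F)F)c3)cc2)ncn1` is not yet measured. It differs from compound 3 by (2-hydroxypropyl)amino in place of methyl on an aromatic carbon. The measured steps that bear on this change all touch the same position on the shared core. The group that enters here resembles the propylamino group of compound 2, so the step from methyl to propylamino is the closest guide: it was a 5.0-fold higher number from compound 2 to compound 3 (0.70 log units; beyond the scatter) in the reverse direction, and from methoxy the same group gave a 130-fold lower number from compound 1 to compound 2 (2.10 log units; beyond the scatter). A lower number, of modest size, is therefore expected for compound 4 in this assay. The expected step is a 4.0-fold lower number from compound 3 to compound 4 (0.60 log units; beyond the scatter). Compound 4 is estimated at 40 nM, within a range from 12 nM to 130 nM.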

Compound 4, half-maximal inhibitory concentration: 32 nM
The estimate for compound 4 lay 1.3-fold (0.10 log units) above the measured number; low and high end bracket the measured number.
By their numbers in this assay, from the lowest: compounds 2 and 4 (each within the scatter of the next); then compound 3; then compound 1.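

The new finding is that the propylamino chain at this position can carry a hydroxy group without a visible loss in this assay: there is no change at the digits printed from compound 2 to compound 4 (within the scatter). The gains seen with propylamino therefore persist with (2-hydroxypropyl)amino, with a 5.0-fold lower number from compound 3 to compound 4 (0.70 log units; beyond the scatter) and a 130-fold lower number from compound 1 to compound 4 (2.10 log units; beyond the scatter), steps that match in size those given by compound 2. No measurement here explains why the hydroxy group is tolerated.

On these data alone, it remains open whether the mirror-image form of the 2-hydroxypropyl chain would behave the same, and whether a longer chain, or a chain ending in an amine or a carboxylic acid, would hold this level. As far as these compounds go, the role of the nitrogen attached to the aromatic carbon is also open, and a butyl or propoxy group in its place would probe it.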